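A few compounds are considered here, and "the series" means these few. Any claim that something is new, unique, unknown or untested is made for them only; others in the source may bear on it.

Measured compounds:
compound 1, `CC1CCCN1c1ccc2cc(NC(=O)CCc3ccc(C(F)(F)F)cc3)ccc2n1`: in an assay on isolated protein for displacement of a labelled ligand from melanin-concentrating hormone receptor 1 (Homo sapiens) (on this read-out higher numbers stand for weaker inhibition and lower numbers for stronger inhibition), compound 1 gives 5 nM;
compound 2, `CCCN(CCC)c1ccc2cc(NC(=O)CCc3ccc(C(F)(F)F)cc3)ccc2n1`: in this assay compound 2 gives 490 nM.

Within the data shown here, compound 2 holds the highest of the two numbers; its only neighbour is compound 1, and the step of a 98-fold higher number from compound 1 to compound 2 (1.99 log units; beyond the scatter) is large and beyond the scatter. Compound 3, `CN(C)c1ccc2cc(NC(=O)CCc3ccc(C(F)(F)F)cc3)ccc2n1`, has not yet been measured. It differs from compound 2 by dimethylamino in place of dipropylamino on an aromatic carbon. Among the measured compounds shown here, the single measured step, a 98-fold higher number from compound 1 to compound 2 (1.99 log units; beyond the scatter), swapped a ring amine for an open-chain one, so it bears on this change only loosely: compound 2 and compound 3 both carry open-chain dialkylamino groups, and no measured pair shows what shortening such chains does. Compound 3 is therefore expected to stay closer to compound 2 than to compound 1. For compound 3 the expected step is a 2.5-fold lower number from compound 2 to compound 3 (0.39 log units; beyond the scatter), a modest lowering that may not exceed the scatter. Compound 3 is estimated at 200 nM, within a range from 40 nM to 1500 nM.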

Compound 3, half-maximal inhibitory concentration: 13 nM
Estimate against measurement, compound 3: 15-fold (1.19 log units) above; the measured number lies below the stated range.
By their numbers in this assay, from the lowest: compound 1; then compound 3; then compound 2.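

At this position, on the aromatic carbon next to the ring nitrogen, an open-chain amine does not by itself give a high number in this assay: dimethylamino in place of dipropylamino brings a 38-fold lower number from compound 2 to compound 3 (1.58 log units; beyond the scatter), so among these compounds the large loss belongs to dipropylamino, not to open-chain amines as a class. Dimethylamino in place of 2-methylpyrrolidin-1-yl brings only a 2.6-fold higher number from compound 1 to compound 3 (0.41 log units; beyond the scatter), a modest step though beyond the scatter, so a ring on this nitrogen is not needed for a low number, although compound 1 stays the lowest of the three. Nothing at hand explains the difference between the two open-chain groups.

Diethylamino would show where between dimethylamino and dipropylamino the number climbs, and that remains open. Also open, as far as these compounds go, is how a pyrrolidin-1-yl group without the methyl, or a morpholine, would behave here.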